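Shortening the ketone chain: compound 2 to compound 3

This account rests on a few compounds, and the source may have more. Where it says the series, first, only, none or still open, it means among the compounds named here.

Among the compounds with values here, compound 2 `Cc1cc(C(=O)O)ccc1OCCCCOc1ccc(C(=O)C(C)C)c(O)c1C` holds the lowest of the two numbers so far: in an assay on HEK293 cells for positive allosteric modulation of metabotropic glutamate receptor 3 (Rattus norvegicus), read by thallium flux, with a stated time of 2.5 min (on this read-out higher numbers stand for larger maximal responses and lower numbers for smaller maximal responses), compound 2 gives 25.2%. Within the data shown here, its only neighbour is compound 1 `CCCC(=O)c1ccc(OCCCCOc2ccc(C(=O)O)cc2C)c(C)c1O`, which in this assay gives 40.5%; the single measured step, a number 15.3 percentage points lower from compound 1 to compound 2 (beyond the scatter), went with isopropyl in place of propyl on a carbonyl carbon. Compound 3 `CCC(=O)c1ccc(OCCCCOc2ccc(C(=O)O)cc2C)c(C)c1O` differs from compound 2 by hydrogen in place of methyl on a saturated chain carbon bound to a carbonyl carbon and a saturated chain carbon. Among the measured compounds shown here, that one step is the only evidence bearing on this change, as it concerns the same chain at the carbonyl. Compound 3 is expected to recover part of that loss, because a number 15.3 percentage points lower from compound 1 to compound 2 (beyond the scatter) is the sole move known on this chain. Compound 3 is therefore estimated at 37%, from 24% to 50%, an expected step of a number 11.8 percentage points higher from compound 2 to compound 3 (beyond the scatter).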

Compound 3, largest response reached (reported as percent of maximum), in percent of the reference or control that the assay uses: 22.7%
For compound 3 the middle estimate is 14.3 percentage points above the measured one, and the stated range ends above it.
By their numbers in this assay, from the lowest: compounds 3 and 2 (each within the scatter of the next); then compound 1.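

In this assay, the propanoyl ketone of compound 3 does not regain the response lost with the isopropylcarbonyl group, with a number 2.5 percentage points lower from compound 2 to compound 3 (within the scatter) on this change. Set against the propyl ketone, a number 17.8 percentage points lower from compound 1 to compound 3 (beyond the scatter) places the change of a single methyl on this chain as a real drop, so among these three ketones only compound 1 stands apart. No measurement given here accounts for this.

Still open, as far as these compounds go, is whether a butyl chain on the carbonyl carbon would exceed compound 1. From the compounds shown here alone, whether an amine at this carbonyl carbon would keep any response is also open.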